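From cyano to 4-(trifluoromethyl)phenoxy: an expected flat step

The source may report more compounds than this note shows. Statements on the series, on what has been measured and on what is new or still open speak of the compounds shown alone.

Of the compounds shown here, three sharing one core have been measured in a functional assay with Homo sapiens as the target; on this read-out lower numbers stand for stronger inhibition and higher numbers for weaker inhibition. Compound 1 `CC(C)[C@H](NC(=O)COc1cccc2ccccc12)C(=O)N[C@@H](CC(=O)O)C(=O)COc1ccc(-c2ccccc2)cc1`, which carries phenyl, gives 38700 nM. Compound 2 `CC(C)[C@H](NC(=O)COc1cccc2ccccc12)C(=O)N[C@@H](CC(=O)O)C(=O)COc1ccc(C(F)(F)F)cc1`, which carries trifluoromethyl, gives 12300 nM, the lowest number of the three. Compound 3 `CC(C)[C@H](NC(=O)COc1cccc2ccccc12)C(=O)N[C@@H](CC(=O)O)C(=O)COc1ccc(C#N)cc1`, which carries cyano, gives 26700 nM, within the scatter of compound 1 and clearly separated from compound 2.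

Compound 4 `CC(C)[C@H](NC(=O)COc1cccc2ccccc12)C(=O)N[C@@H](CC(=O)O)C(=O)COc1ccc(Oc2ccc(C(F)(F)F)cc2)cc1` keeps the core and has 4-(trifluoromethyl)phenoxy in place of cyano on an aromatic carbon. Among the compounds with values here, no measured compound carries this group, so the evidence is indirect. Cyano in place of phenyl gave a 1.4-fold lower number from compound 1 to compound 3 (0.16 log units; within the scatter), and trifluoromethyl in place of phenyl gave a 3.1-fold lower number from compound 1 to compound 2 (0.50 log units; beyond the scatter). Cyano in place of trifluoromethyl gave a 2.2-fold higher number from compound 2 to compound 3 (0.34 log units; beyond the scatter). The entering group holds both an aromatic ring and a trifluoromethyl, and these steps point different ways. The first suggests little change, while the others allow a modest drop at most in either direction from the values seen so far. No step beyond the scatter is therefore expected, the estimate being a 1.1-fold lower number from compound 3 to compound 4 (0.03 log units; within the scatter). Compound 4 is estimated at 25000 nM, with an expected range from 9000 nM to 70000 nM.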

Compound 4, half-maximal inhibitory concentration: 24900 nM
Estimate against measurement, compound 4: 1.0-fold (0.00 log units) above, within the range that was stated.
By their numbers in this assay, from the lowest: compound 2; then compounds 4, 3 and 1 (each within the scatter of the next).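

In this assay, putting 4-(trifluoromethyl)phenoxy in place of cyano gives a 1.1-fold lower number from compound 3 to compound 4 (0.03 log units; within the scatter) even though the entering group is far larger and brings a six-membered aromatic ring, so on this aromatic carbon, para to a large group, the added bulk alone produces no step beyond the scatter. The comparison with phenyl gives a 1.6-fold lower number from compound 1 to compound 4 (0.19 log units; within the scatter) and the comparison with a lone trifluoromethyl gives a 2.0-fold higher number from compound 2 to compound 4 (0.31 log units; beyond the scatter) and thus shows that a trifluoromethyl at the end of the larger group does not reproduce the number of compound 2, which is now the only one of the four set apart from the others. No independent evidence is available to explain these differences.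

The four groups shown leave open whether a phenoxy without the trifluoromethyl would stay with compounds 1, 3 and 4 or move toward compound 2. From the compounds shown here alone, it also remains open whether an amine or a carboxylic acid on this aromatic carbon would shift the number in either direction beyond the narrow span seen here.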